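The compounds below may be only part of what the source reports. "The series", "measured", "known", "first", "only" and "open" are said of these compounds alone.

Working notes on a short series built on the shared core of compound 1. In a functional assay on cells (Cancer cell lines, Homo sapiens) for cytotoxicity, with a stated time of 48 h (on this read-out higher numbers stand for weaker inhibition of growth and lower numbers for stronger inhibition of growth), compound 1 `COc1ccc(CN2C(=O)/C(=C\c3cc(OC)c(OC)c(OC)c3)c3ccccc32)cc1` gives 2500 nM and holds the lowest of the two numbers recorded so far, although the gap to compound 2 is within the scatter, so no order between the two is claimed. In this assay compound 2 `COc1cc(/C=C2\C(=O)N(C)c3ccc(Cl)cc32)cc(OC)c1OC` gives 4300 nM; it differs from compound 1 in more than one place, and the two values are simply set side by side. Compound 3 `COc1cc(/C=C2\C(=O)N(Cc3ccc(Cl)cc3)c3ccccc32)cc(OC)c1OC` has not yet been measured in this assay. It differs from compound 1 by chloro in place of methoxy on an aromatic carbon, the change sitting on an aromatic carbon of a six-membered aromatic ring of carbon only, para to a large group, so that 4-methoxybenzyl becomes 4-chlorobenzyl. Within the data shown here, no measured pair isolates this change, and the two numbers at hand give no direction for it. The step from compound 1 to compound 3 is therefore expected to be no change at the digits printed from compound 1 to compound 3 (within the scatter), within the scatter. Compound 3 is estimated to come out near 2500 nM, in a range from 1000 nM to 6000 nM.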

Compound 3, concentration for 50% growth inhibition: 3400 nM
Compound 3: middle estimate off by 1.4-fold (0.13 log units), on the low side; the range from low to high includes it.
By their numbers in this assay, from the lowest: compounds 1, 3 and 2 (each within the scatter of the next).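

In this assay, the series now has its first pair differing in one place: chloro in place of methoxy on an aromatic carbon, para to a large group, gives a 1.4-fold higher number from compound 1 to compound 3 (0.13 log units; within the scatter). The position therefore carries either 4-methoxybenzyl or 4-chlorobenzyl with no difference that can be read in this assay, although the swap removes methoxy, with its hydrogen-bond acceptor, and brings in chloro, which has none. No measurement at hand bears on the reason for this result.

The compounds shown leave open whether the same place would accept an amine, a carboxylic acid or a longer chain such as butoxy with the number still within the scatter of compound 1, as this pair covers only two groups. Also open, as far as these compounds go, is whether chloro in place of methoxy would read the same way on a core that carries other changes, since compound 2 differs from both compound 1 and compound 3 in more than one place and gives no matched comparison.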